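The source may report more compounds than this note shows. Statements on the series, on what has been measured and on what is new or still open speak of the compounds shown alone.

Compound 2 `C=C1[C@@H](OC(C)=O)C[C@@H]2[C@](C)(CO[Si](C)(C)C(C)(C)C)[C@H](OC(C)=O)CC[C@@]2(C)[C@@H]1C[C@@H](Nc1ccc(C(=O)O)cc1)C1=CCOC1=O` carries a silyl-protected primary alcohol and a 4-carboxyphenyl on the amine nitrogen. In a functional assay on KB cells (Homo sapiens) for cytotoxicity, read by sulforhodamine B assay (on this read-out lower numbers stand for stronger inhibition and higher numbers for weaker inhibition), compound 2 gives 5540 nM, the lowest of the two numbers recorded. Compound 3 `C=C1[C@@H](OC(C)=O)C[C@@H]2[C@](C)(CO[Si](C)(C)C(C)(C)C)[C@H](OC(C)=O)CC[C@@]2(C)[C@@H]1C[C@@H](Nc1cccc2ccccc12)C1=CCOC1=O` gives 8930 nM; the step of a 1.6-fold higher number from compound 2 to compound 3 (0.21 log units; within the scatter). Compound 1 `C=C1[C@@H](OC(C)=O)C[C@@H]2[C@](C)(COC=O)[C@H](OC(C)=O)CC[C@@]2(C)[C@@H]1C[C@@H](Nc1ccc(OC)c(OC)c1)C1=CCOC1=O` carries a formyl ester in place of the silyl group and a 3,4-dimethoxyphenyl on the amine; in this assay compound 1 reaches only a limit, > 50000 nM. Compound 4 `C=C1[C@@H](OC(C)=O)C[C@@H]2[C@](C)(COC=O)[C@H](OC(C)=O)CC[C@@]2(C)[C@@H]1C[C@@H](Nc1ccc(C(=O)O)cc1)C1=CCOC1=O`, still to be measured, differs from compound 2 by a group of 2 heavy atoms (1 carbon, 1 oxygen; no ring) in place of a group of 7 heavy atoms (6 carbon, 1 silicon; no ring), on an oxygen on a saturated carbon. Going by the values given here, no measured step covers this exchange: the single comparison available alters the aryl group, not the ester, and compound 1, the only formyl-bearing compound measured, also differs in the aryl group, so its limit cannot be split between the two changes. A loss beyond the scatter is nevertheless expected for compound 4, estimated at 15000 nM in this assay, between 5000 nM and 45000 nM. The expected step of a 2.7-fold higher number from compound 2 to compound 4 (0.43 log units; beyond the scatter) reflects that reading.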

Compound 4, half-maximal inhibitory concentration: > 50000 nM
Compound 4 was reported as a limit; the forecaster's own chance of this, stated with the estimate: 25%; middle value at least 3.3-fold (0.52 log units) from the limit.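

In this assay, the exchange of the silyl-bearing group for formyl on an oxygen on a saturated carbon now has a step of its own, with the 4-carboxyphenyl on the amine nitrogen held fixed: an at least 9.0-fold higher number from compound 2 to compound 4 (0.95 log units; beyond the scatter) shows a loss that compound 1 could not separate from its change of aryl group. The size of this step is open at its upper end, as compound 4 stands at a limit of the assay: the limit of > 50000 nM in this assay, at which 2 of the 4 values shown sit. The step between compound 1 and compound 4 cannot be read, so the aryl exchange among the formyl esters remains without a size.

As far as these compounds go, whether a free primary alcohol or an acetyl ester on this oxygen behaves like the silyl-bearing group or like formyl remains open. Also open, from the compounds shown here alone, is whether the same exchange costs as much with naphthalen-1-yl on the amine nitrogen.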